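This account rests on a few compounds, and the source may have more. Where it says the series, first, only, none or still open, it means among the compounds named here.

Compound 1, `CC1=C(C(=O)CC(C)C)C(c2ccoc2)NC(=O)N1`, gives 23% in an assay on membranes from CHO cells for displacement of a labelled ligand from adenosine receptor A1 (Homo sapiens), read by scintillation counting, with a stated time of 60 min, tested at 1 uM; a higher number here means more inhibition at the concentration tested (going by the name of the read-out), a lower number less inhibition.
Compound 2, `CC1=C(C(N)=O)C(c2ccoc2)NC(=O)N1`, gives 1% in this assay.
Compound 3, `CCSC(=O)C1=C(C)NC(=O)NC1c1ccoc1`, gives 3% in this assay.

Compound 3 stands second highest of the three numbers in this assay; its nearest neighbour is compound 2, and their difference, a number 2 percentage points higher from compound 2 to compound 3 (within the scatter), lies within the scatter, so no order between these two can be read. For the measured compounds named here, the only step beyond the scatter that touches compound 3 is a number 20 percentage points lower from compound 1 to compound 3 (beyond the scatter), where ethylsulfanyl replaces isobutyl on a carbonyl carbon. Compound 4, `CC1=C(C(=O)SC(C)C)C(c2ccoc2)NC(=O)N1`, has not been measured; it differs from compound 3 by methyl in place of hydrogen on a saturated chain carbon bound to a saturated chain carbon and a sulfur, so that ethylsulfanyl becomes isopropylsulfanyl. Going by the values given here, no measured step alters this chain, and the measured steps bear on it only loosely: the two steps from compound 1 show that the group on the carbonyl carbon matters, but both are exchanges of whole groups, not additions of a methyl. One therefore expects a step of a number 3 percentage points higher from compound 3 to compound 4 (within the scatter) in this assay, small and within the scatter, if anything slightly upward. Compound 4 is estimated at 6%, with a range from 0% to 20%.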

Compound 4, a percentage reported as inhibition, at one concentration (the size of the read-out at that concentration, not a potency): 9%
Estimate against measurement, compound 4: 3 percentage points below; the measured number falls inside the stated range.
By their numbers in this assay, from the lowest: compounds 2, 3 and 4 (each within the scatter of the next); then compound 1.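

In this assay, methyl in place of hydrogen on a saturated chain carbon bound to a saturated chain carbon and a sulfur, which turns ethylsulfanyl into isopropylsulfanyl, gives the step of a number 6 percentage points higher from compound 3 to compound 4 (within the scatter), which cannot be read. The same holds for the step of a number 8 percentage points higher from compound 2 to compound 4 (within the scatter), since both of these steps lie within the scatter. The step of a number 14 percentage points lower from compound 1 to compound 4 (beyond the scatter) is modest and beyond the scatter, so the gap to compound 1 seen with ethylsulfanyl remains with isopropylsulfanyl. Nothing available explains this result.

Going by these compounds, whether a longer chain on the sulfur, such as butylsulfanyl, or a phenyl group there would give a readable step remains open. On these data alone, compound 1 alone carries isobutyl on the carbonyl carbon, so it is also open whether a propyl or cyclopentyl group there would give a similar number.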